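The source may report more compounds than this note shows. Statements on the series, on what has been measured and on what is new or still open speak of the compounds shown alone.

In an assay on HEK293 cells for displacement of a labelled ligand from NPC1-like intracellular cholesterol transporter 1 (Homo sapiens) (on this read-out higher numbers stand for weaker inhibition and lower numbers for stronger inhibition), compound 2 `COC(=O)CCCNC(=O)CN1CN(c2ccccc2)C2(CCN(C(=O)c3ccc(C4CCCCC4)cc3)CC2)C1=O` gives 2500 nM, the lowest of the three numbers, though the gaps to the other two are within the scatter: compound 1 `CCOC(=O)C1CCN(C(=O)CN2CN(c3ccccc3)C3(CCN(C(=O)c4ccc(C(C)(C)C)cc4)CC3)C2=O)CC1` gives 3100 nM and compound 3 `CC(C)(C)OC(=O)NCCCCNC(=O)CN1CN(c2ccccc2)C2(CCN(C(=O)c3ccc(C4CCCCC4)cc3)CC2)C1=O` gives 4600 nM. Compound 4 `O=C(CN1CN(c2ccccc2)C2(CCN(C(=O)c3ccc(C4CCCCC4)cc3)CC2)C1=O)N1CCCCC1` has not yet been measured. It differs from compound 2 by piperidin-1-yl in place of (3-(methoxycarbonyl)propyl)amino on a carbonyl carbon. Among the compounds with values here, only one measured step touches this part of the molecule, a 1.8-fold higher number from compound 2 to compound 3 (0.26 log units; within the scatter), where the end of the chain was exchanged and the number hardly moved. That step kept the amino group and changed only its chain end, so it is a loose guide to a ring replacing the whole group. The expectation for compound 4 in this assay is therefore no step beyond the scatter, a 1.1-fold higher number from compound 2 to compound 4 (0.03 log units; within the scatter), with an estimated 2700 nM and a range from 1000 nM to 7000 nM.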

Compound 4, half-maximal inhibitory concentration: 1100 nM
Compound 4: middle estimate off by 2.5-fold (0.39 log units), on the high side; measured number inside the range.
By their numbers in this assay, from the lowest: compound 4; then compounds 2, 1 and 3 (each within the scatter of the next).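

In this assay, within the data shown here, piperidin-1-yl in place of (3-(methoxycarbonyl)propyl)amino gives a 2.3-fold lower number from compound 2 to compound 4 (0.36 log units; beyond the scatter) and is the first step at this carbonyl carbon to lie beyond the scatter, though only modestly. The number therefore responds when the whole group is exchanged, a change that also removes the amide hydrogen and the ester. Nothing measured here explains the shift. Still open, going by these compounds, is whether the ring itself matters or the loss of the amide hydrogen or ester. Pyrrolidine, morpholine or dimethylamino on the same carbonyl carbon would help separate these.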